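Compound 4: a chlorine in place of the pyridine

The source may hold more compounds than are shown below. What is called first, only, known or untested is meant among the compounds shown, and "the series" means these compounds.

compound 1 `COc1ccc(-c2noc(C3CCNCC3)n2)cc1OC1CCCC1` gives 1540 nM
compound 2 `COc1ccc(-c2noc(-c3ccc(F)cc3)n2)cc1OC1CCCC1` gives 210000 nM
compound 3 `COc1ccc(-c2noc(-c3cccnc3)n2)cc1OC1CCCC1` gives > 1000000 nM, a limit and not a number

These values come from a functional assay on HCT-116 cells (Homo sapiens) for antiproliferative activity, read by MTT assay, with a stated time of 24 h; on this read-out lower numbers stand for stronger inhibition and higher numbers for weaker inhibition. Compound 3 stands at > 1000000 nM, which is a limit of the assay and not a number. On the numbers shown, this is the limit of > 1000000 nM in this assay, at which 1 of the 3 values shown sits.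

Compound 4 `COc1ccc(-c2noc(-c3ccc(Cl)cc3)n2)cc1OC1CCCC1` carries 4-chlorophenyl in place of pyridin-3-yl on an aromatic carbon. The nearest guide is an at least 4.7-fold higher number from compound 2 to compound 3 (0.67 log units; beyond the scatter), a step beyond the scatter that puts pyridin-3-yl in place of 4-fluorophenyl. The change here runs the opposite way, back to a six-membered aromatic ring of carbon only, so compound 2 at 210000 nM is the best model. The far larger steps a 140-fold higher number from compound 1 to compound 2 (2.13 log units; beyond the scatter) and an at least 640-fold higher number from compound 1 to compound 3 (2.81 log units; beyond the scatter) both involve losing piperidin-4-yl, which compound 4 also lacks, so no return to the level of compound 1 is expected.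

In this assay, the expected change is an at least 5.0-fold lower number from compound 3 to compound 4 (0.69 log units; beyond the scatter), an at least modest step toward a lower number. For compound 4 the estimate is 200000 nM, with an expected range from 70000 nM to 600000 nM.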

Compound 4, half-maximal inhibitory concentration: > 1000000 nM
Compound 4 gave a limit, no number; the forecaster's own chance of this, stated with the estimate: 15%; middle value at least 5.0-fold (0.69 log units) away from the limit.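

Changing one halogen on this ring matters in this series: chloro in place of fluoro on an aromatic carbon gives an at least 4.7-fold higher number from compound 2 to compound 4 (0.67 log units; beyond the scatter), so a 4-fluorophenyl result does not carry over to 4-chlorophenyl in this assay. Compound 4 gives a limit, not a number, and it now shares that limit with compound 3, so the step between these two cannot be read: the limit of > 1000000 nM in this assay, at which 2 of the 4 values shown sit. Replacing piperidin-4-yl with 4-chlorophenyl gives an at least 640-fold higher number from compound 1 to compound 4 (2.81 log units; beyond the scatter), which extends to a third aromatic group the loss already seen on leaving piperidin-4-yl.

From the compounds shown here alone, whether compound 1 owes its lower number to the piperidine ring itself or only to its amine remains open. An aminomethyl group or a longer aminoethyl chain on the same carbon could separate the two, and a carboxylic acid there would add a further contrast.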